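Methyl in place of chloro on compound 2

A few compounds are considered here, and "the series" means these few. Any claim that something is new, unique, unknown or untested is made for them only; others in the source may bear on it.

In an ADME assay on microsomes from liver (Rattus norvegicus) for metabolic stability, read by LC-MS, with a stated time of 30 min, tested at 1 uM (on this read-out lower numbers stand for a less stable compound and higher numbers for a more stable compound), compound 2 `CCNCc1cc(Cl)cc(Nc2nc3cc(F)c(F)cc3n2Cc2ccc(C(F)(F)F)cc2)c1O` gives 98% after the test period, so nearly all of it remains. Compound 1 `Cc1cc(CNC(C)(C)C)c(O)c(Nc2nc3cc(F)c(F)cc3n2Cc2ccc(C(F)(F)F)cc2)c1` gives 89% in this assay and the two numbers lie within the usual scatter of each other, so neither can be ranked above the other.

Compound 3 `CCNCc1cc(C)cc(Nc2nc3cc(F)c(F)cc3n2Cc2ccc(C(F)(F)F)cc2)c1O` is compound 2 with a single change: methyl in place of chloro on an aromatic carbon, para to a hydroxy group (methyl in place of chloro on an aromatic carbon). Among the compounds with values here, no two measured compounds differ in one place only, so the effect of this swap has never been seen directly. The nearest guide is compound 1, which also carries a methyl group and gives 89% even though it differs from compound 2 elsewhere too. On that thin evidence, no step beyond the scatter is expected, at most a slight fall. The expected change is a number 7 percentage points lower from compound 2 to compound 3 (within the scatter) and it stays within the scatter. For compound 3 the estimated value is 91% with an expected range of 77% to 100% when it is measured.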

Compound 3, percent of the compound remaining: 77%
Compound 3: middle estimate off by 14 percentage points, on the high side; measured number inside the range.
By their numbers in this assay, from the lowest: compound 3; then compounds 1 and 2 (each within the scatter of the next).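

In this assay the position para to a hydroxy group proves to matter: methyl in place of chloro there gives a number 21 percentage points lower from compound 2 to compound 3 (beyond the scatter) and so moves the number beyond the scatter, something the earlier pair of compounds, which differ in more than one place, could not show. The amine nitrogen matters as well, since ethyl in place of tert-butyl gives a number 12 percentage points lower from compound 1 to compound 3 (beyond the scatter) with the methyl on the aromatic ring unchanged, which leaves compound 3 lowest of the three, with its steps to both others beyond the scatter. Nothing measured here explains why either change lowers the number.

From the compounds shown here alone, each step rests on a single pair of compounds, so it remains open whether the chloro effect would look the same with tert-butyl on the amine nitrogen, or the tert-butyl effect the same with chloro on the aromatic ring. Going by these compounds, how a fluoro or a methoxy group at the aromatic position would compare with chloro and methyl, or an isopropyl or cyclopropyl group on the amine nitrogen with ethyl and tert-butyl, also remains open.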